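The source may report more compounds than this note shows. Statements on the series, on what has been measured and on what is new or still open speak of the compounds shown alone.

Compound 3 `O=C(O)c1ccc(C(=O)/C(=C\c2ccc(Br)cc2)SCc2ccc(F)cc2)cc1` carries no nitro group; in a functional assay on DU-145 cells (Homo sapiens) for inhibition, read by trypan blue exclusion, with a stated time of 96 h (a higher number here means a weaker inhibitor of growth, a lower number a stronger inhibitor of growth), compound 3 gives only a limit, > 100000 nM. Compound 3 thus stands at the limit of > 100000 nM in this assay, at which 1 of the 3 values shown sits. Compound 1 `O=C(O)c1ccc(C(=O)/C(=C\c2ccc(Br)c([N+](=O)[O-])c2)SCc2ccc(F)cc2)cc1` gives 1000 nM in this assay, and compound 2 `CC(=O)Nc1ccc(/C=C(/SCc2ccc(F)cc2)C(=O)c2ccc(C(=O)O)cc2)cc1[N+](=O)[O-]` gives 10000 nM. Among the compounds with values here, two measured steps bear on the move to compound 4 `O=C(O)c1ccc(C(=O)/C(=C\c2ccc(O)c([N+](=O)[O-])c2)SCc2ccc(F)cc2)cc1`: the large step of an at least 100-fold higher number from compound 1 to compound 3 (2.00 log units; beyond the scatter) shows what removing the nitro costs, and the modest step of a 10-fold higher number from compound 1 to compound 2 (1.00 log units; beyond the scatter) shows what replacing bromo with acetamido costs. The change here is 4-hydroxy-3-nitrophenyl in place of 4-bromophenyl on a double-bonded chain carbon bound to a double-bonded chain carbon, restoring the nitro while exchanging bromo for hydroxy. Compound 4 is therefore expected to show a large fall in number, estimated as an at least 33-fold lower number from compound 3 to compound 4 (1.52 log units; beyond the scatter). Compound 4 is estimated at 3000 nM in this assay, within 800 nM to 20000 nM.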

Compound 4, concentration for 50% growth inhibition: > 100000 nM
Compound 4: a limit, no number; the forecaster's own chance of this, stated with the estimate: 10%; middle value at least 33-fold (1.52 log units) from the limit.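

Hydroxy in place of bromo gives an at least 100-fold higher number from compound 1 to compound 4 (2.00 log units; beyond the scatter), and hydroxy in place of acetamido gives an at least 10-fold higher number from compound 2 to compound 4 (1.00 log units; beyond the scatter). The nitro alone therefore does not secure growth inhibition in this assay: compound 1, compound 2 and compound 4 all carry it, and the group on the neighbouring aromatic carbon still changes the number. Compound 4 gives only a limit, and the step from compound 3 to compound 4 cannot be read: the limit of > 100000 nM in this assay, at which 2 of the 4 values shown sit.

Open, from the compounds shown here alone, is whether a methoxy or an amine in place of the hydroxy, with the nitro kept, would bring the number back towards that of compound 1.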